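Homologating the acetoxymethyl side chain of an enone

A few compounds are considered here, and "the series" means these few. Any claim that something is new, unique, unknown or untested is made for them only; others in the source may bear on it.

Compound 2 `COc1ccc(C(=O)/C(=C/C2CCCCC2)COC(C)=O)cc1`: 24000 nM
Compound 1 `CCC(/C=C(\COC(C)=O)C(=O)c1ccc(OC)cc1)CC`: 13700 nM

In a functional assay on MCF7 cells (Homo sapiens) for inhibition, read by XTT assay, with a stated time of 48 h (on this read-out higher numbers stand for weaker inhibition and lower numbers for stronger inhibition), compound 2 gives 24000 nM. For the measured compounds named here, its only neighbour, compound 1, gives 13700 nM, and the step of a 1.8-fold higher number from compound 1 to compound 2 (0.24 log units; within the scatter) leaves the two within the scatter of each other. Compound 3 `COc1ccc(C(=O)/C(=C/C2CCCCC2)CC(C)OC(C)=O)cc1` differs from compound 2 by 1-acetoxyethyl in place of acetoxy on a saturated chain carbon bound to a double-bonded chain carbon. Going by the values given here, no measured step touches this part of the molecule, so the change is untested. The analyst therefore expects no step beyond the scatter in this assay and estimates for compound 3 a value of 24000 nM, within 8000 nM to 72000 nM, a step of no change at the digits printed from compound 2 to compound 3 (within the scatter).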

Compound 3, half-maximal inhibitory concentration: > 100000 nM
Compound 3 gave a limit, no number; the forecaster's own chance of this, stated with the estimate: 10%; middle value at least 4.1-fold (0.61 log units) from the limit.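

For the compounds shown here, replacing acetoxymethyl with 2-acetoxypropyl gives an at least 4.1-fold higher number from compound 2 to compound 3 (0.61 log units; beyond the scatter) in this assay, the first step beyond the scatter here, whereas the change from pentan-3-yl to cyclohexyl stayed within it. Compound 3 gives > 100000 nM, which is a limit of the assay and not a number. The step therefore fixes only a minimum size: the limit of > 100000 nM in this assay, at which 1 of the 3 values shown sits.

On these data alone, it remains open how an amine or a carboxylic acid in place of the acetoxy group would read in this assay. As far as these compounds go, it also remains open whether a longer chain would read like 2-acetoxypropyl.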